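Aryl swap at the carbonyl: expectation for compound 4

This account rests on a few compounds, and the source may have more. Where it says the series, first, only, none or still open, it means among the compounds named here.

Compound 1 `COc1ccc(C(=O)/C=C/c2cc(-c3cc(OC)c(OC)c(OC)c3)n3nc(-c4ccccc4)cc3n2)cc1` is one of three analogues measured in a functional assay on MDA-MB-231 cells (Homo sapiens) for antiproliferative activity, read by MTT assay, with a stated time of 24 h; a lower number here means a stronger inhibitor, a higher number a weaker inhibitor. Compound 1 gives 13200 nM; compound 2 `COc1ccc(C(=O)/C=C/c2cc(-c3ccc(OC)c(OC)c3)n3nc(-c4ccccc4)cc3n2)cc1` gives 13900 nM and compound 3 `COc1ccc(C(=O)/C=C/c2cc(-c3ccc(OC)c(OC)c3)n3nc(-c4ccccc4)cc3n2)cc1OC` gives 2600 nM. Compound 1 thus stands second highest of the three, close to compound 2 and well apart from compound 3. The two measured steps, a 1.1-fold higher number from compound 1 to compound 2 (0.02 log units; within the scatter) and a 5.3-fold lower number from compound 2 to compound 3 (0.73 log units; beyond the scatter), both concern a methoxy on an aromatic carbon of the aryl group on the shared core, not the ring on the carbonyl carbon. Compound 4 `COc1cc(-c2cc(/C=C/C(=O)c3ccc(C)c(C)c3)nc3cc(-c4ccccc4)nn23)cc(OC)c1OC` alters that carbonyl-side ring: 3,4-dimethylphenyl in place of 4-methoxyphenyl on a carbonyl carbon. Neither measured step bears on this change, so no step beyond the scatter is expected in this assay. Compound 4 is therefore estimated at 13000 nM, with a range from 5000 nM to 35000 nM. The expected step is a 1.0-fold lower number from compound 1 to compound 4 (0.01 log units; within the scatter).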

Compound 4, half-maximal inhibitory concentration: 13500 nM
Estimate against measurement, compound 4: 1.0-fold (0.02 log units) below; the range from low to high includes it.
By their numbers in this assay, from the lowest: compound 3; then compounds 1, 4 and 2 (each within the scatter of the next).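

Among these compounds, with the core of compound 1 held fixed, 3,4-dimethylphenyl in place of 4-methoxyphenyl on a carbonyl carbon gives a 1.0-fold higher number from compound 1 to compound 4 (0.01 log units; within the scatter) in this assay and is the first direct reading of a full ring exchange at this position. In this single pair, a ring bearing no methoxy stands within the scatter of the 4-methoxyphenyl ring. No available evidence bears on this result.

Still open, as far as these compounds go, is how this ring would read carrying an amine or a carboxylic acid, or an ethyl chain in place of methyl. From the compounds shown here alone, whether the same exchange reads alike on the core of compound 2 also remains open.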